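Working notes: trifluoromethylsulfonyl for trifluoromethoxy on the aryl sulfonamide

A few compounds are considered here, and "the series" means these few. Any claim that something is new, unique, unknown or untested is made for them only; others in the source may bear on it.

Measured compounds and their values:
- compound 1 `CN(C)CC[C@H](CSc1ccccc1)Nc1ccc(S(=O)(=O)NC(=O)c2ccc(N3CCN(Cc4ccccc4-c4ccc(Cl)cc4)CC3)cc2)cc1OC(F)(F)F`: 5080 nM
- compound 2 `CN(C)CC[C@H](CSc1ccccc1)Nc1ccc(S(=O)(=O)NC(=O)c2ccc(N3CCN(CC4=C(c5ccc(Cl)cc5)CCC4)CC3)cc2)cc1[N+](=O)[O-]`: 691 nM
- compound 3 `CN(C)CC[C@H](CSc1ccccc1)Nc1ccc(S(=O)(=O)NC(=O)c2ccc(N3CCN(CC4=C(c5ccc(Cl)cc5)CCCC4)CC3)cc2)cc1[N+](=O)[O-]`: 25.7 nM

In a functional assay on NCI-H146 cells (Homo sapiens) for cytotoxicity, with a stated time of 48 h, in the presence of a further agent that is not named here (a lower number here means that less compound is needed, a higher number that more compound is needed for the effect), compound 1 gives 5080 nM, the highest of the three numbers. Compound 2 gives 691 nM, and compound 3 gives 25.7 nM; both gaps to compound 1 lie beyond the scatter. Compound 2 and compound 3 each differ from compound 1 in more than one place, so neither gap can be tied to a single change.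

Compound 4 `CN(C)CC[C@H](CSc1ccccc1)Nc1ccc(S(=O)(=O)NC(=O)c2ccc(N3CCN(Cc4ccccc4-c4ccc(Cl)cc4)CC3)cc2)cc1S(=O)(=O)C(F)(F)F` differs from compound 1 at one position: (trifluoromethyl)sulfonyl in place of trifluoromethoxy on an aromatic carbon. The substituent sits on an aromatic carbon of a six-membered aromatic ring of carbon only, ortho to a large group and meta to a large group. For the measured compounds named here, no measured pair isolates this exchange, so the direction of the step rests on the pattern among the three numbers, in which every variation away from compound 1 gave a lower number, and on the size of the group entering.

The step from compound 1 to compound 4 is expected to be a modest lowering, around a 2.5-fold lower number from compound 1 to compound 4 (0.40 log units; beyond the scatter), not far beyond the scatter. Compound 4 is therefore estimated at 2000 nM in this assay, within a range of 500 nM to 8000 nM.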

Compound 4, half-maximal effective concentration: 39.4 nM
Estimate against measurement, compound 4: 51-fold (1.71 log units) above, outside the stated range (below it).
By their numbers in this assay, from the lowest: compounds 3 and 4 (each within the scatter of the next); then compound 2; then compound 1.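

In this assay, (trifluoromethyl)sulfonyl in place of trifluoromethoxy on an aromatic carbon, ortho to a large group and meta to a large group, gives a 130-fold lower number from compound 1 to compound 4 (2.11 log units; beyond the scatter), a large step and the first in this set that can be tied to a single change. With everything else in compound 1 held constant, this one substituent is enough to move the number well beyond the scatter, so the position is clearly not indifferent to which group it carries, a point the earlier gaps, each spanning more than one change, could not establish. Nothing measured here bears on the reason for a step of this size, so it stands as an observation without an assigned cause.

For the compounds shown here, the single pair leaves open whether the exchange gives a step of similar size on the core of compound 3, and how the nitro group would stand on the core of compound 1. As far as these compounds go, how a methylsulfonyl group, a nitrile, or a plain hydrogen at this place would compare with trifluoromethoxy and (trifluoromethyl)sulfonyl also remains open.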